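The source may report more compounds than this note shows. Statements on the series, on what has been measured and on what is new or still open speak of the compounds shown alone.

Two compounds, compound 1 `CC(C)(CO)[C@@H](O)C(=O)N/C=C\C(=O)OCc1ccccc1` and compound 2 `CC(C)(CO)[C@H](O)C(=O)N/C=C\C(=O)OCc1ccccc1`, have been tested in an ADME assay on WI-38 cells (Homo sapiens) for inhibition, read by CellTiter-Glo, with a stated time of 48 h, tested at 100 uM; a higher number here means more inhibition at the concentration tested (going by the name of the read-out), a lower number less inhibition. In this assay compound 1 gives 4%, and compound 2 gives -2%. The step of a number 6 percentage points lower from compound 1 to compound 2 (within the scatter) is small; the only thing that separates the pair is the fact that compounds 1 and 2 differ only in the configuration as drawn. On the numbers shown, compound 2 and compound 1 lie within the scatter of each other, so their numbers in this assay count as level.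

The next compound, compound 3 `CC(C)(CO)[C@@H](O)C(=O)N/C=C/C(=O)OCc1ccccc1`, is again made of the same atoms and bonds. Compared with compound 2, (the two compounds have the same atoms and bonds and differ only in configuration as drawn: 2 of 2 stereo elements differ; a stereocentre at a saturated chain carbon is drawn S in compound 2 and R in compound 3; a double bond is drawn Z in compound 2 and E in compound 3). The measured step from compound 1 to compound 2 bears on the switch at the stereocentre alone, and it stayed within the scatter. Going by the values given here, no measured pair speaks to the switch of the double bond from Z to E. Given this, the expected step of a number 3 percentage points higher from compound 2 to compound 3 (within the scatter) is none beyond the scatter, and compound 3 is estimated to give 1% in this assay, with a range from -12% to 14%.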

Compound 3, a percentage reported as inhibition, at one concentration (the size of the read-out at that concentration, not a potency): 19%
Estimate against measurement, compound 3: 18 percentage points below; measured number above the stated range.
By their numbers in this assay, from the lowest: compounds 2 and 1 (each within the scatter of the next); then compound 3.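

Going by these compounds alone, compound 3 brings the first step beyond the scatter in this assay, and the step of a number 15 percentage points higher from compound 1 to compound 3 (beyond the scatter) can be tied to the double bond going from Z to E, because nothing else separates this pair: the fact that compounds 1 and 3 differ only in the configuration as drawn. The step of a number 21 percentage points higher from compound 2 to compound 3 (beyond the scatter) carries two switches at once, the double bond and the stereocentre, so it cannot be split between them on its own: the fact that compounds 2 and 3 differ only in the configuration as drawn. Read with the earlier pair, in which the stereocentre alone stayed within the scatter, this suggests that among these three compounds the shape of the double bond counts for more than the stereocentre, although the rise is only modest and rests on a single reading at one concentration.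

With only one E compound among those shown, it remains open whether the stereocentre has any influence when the double bond is drawn E. It is also open whether the rise with the E double bond would persist with a carboxylic acid in place of the ester, or with a longer chain at that end of the molecule.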